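Chloro to fluoro on the benzamide of compound 3

The source may report more compounds than this note shows. Statements on the series, on what has been measured and on what is new or still open speak of the compounds shown alone.

Compound 3 `CN1CCC(=C(F)c2cccc(NC(=O)c3ccc(Cl)cc3)n2)CC1` is measured in an ADME assay on the whole organism (Rattus norvegicus, strain Sprague-Dawley) for pharmacokinetics, read by LC-MS, with a stated time of 24 h, at a dose of 1 mg/kg by the intravenous route (on this read-out lower numbers stand for narrower distribution and higher numbers for wider distribution into tissues), at 20.3 L/kg. Compound 2 `CN1CCC(=C(F)c2cccc(NC(=O)c3ccc(Cl)cc3F)n2)CC1` gives 20.1 L/kg and compound 1 `CN1CCC(=C(F)c2cccc(NC(=O)c3ccc(F)cn3)n2)CC1` gives 11 L/kg. The three numbers sit close together: a 1.0-fold higher number from compound 2 to compound 3 (0.00 log units; within the scatter) and a 1.8-fold higher number from compound 1 to compound 3 (0.27 log units; within the scatter), so compound 3 stands at the wide end of the group only in name, not beyond the scatter.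

Compound 4 `CN1CCC(=C(F)c2cccc(NC(=O)c3ccc(F)cc3)n2)CC1` differs from compound 3 by fluoro in place of chloro on an aromatic carbon. Going by the values given here, no measured step swaps these two halogens. The nearest information is the pair of aryl exchanges, a 1.8-fold higher number from compound 1 to compound 2 (0.26 log units; within the scatter) and a 1.8-fold higher number from compound 1 to compound 3 (0.27 log units; within the scatter), and the loss of a fluoro on the aromatic carbon, a 1.0-fold higher number from compound 2 to compound 3 (0.00 log units; within the scatter), none of which moved this assay beyond its scatter. On that basis, the expected change in this assay is a 1.3-fold lower number from compound 3 to compound 4 (0.10 log units; within the scatter), meaning no shift beyond the scatter, with a slight lean toward a narrower distribution as the only guess worth recording. The estimate for compound 4 is therefore 16 L/kg, with a range of 8 L/kg to 32 L/kg.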

Compound 4, volume of distribution at steady state: 17.3 L/kg
For compound 4 the middle estimate is 1.1-fold (0.03 log units) below the measured one; low and high end bracket the measured number.
By their numbers in this assay, from the lowest: compounds 1, 4, 2 and 3 (each within the scatter of the next).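

Going by these compounds alone, the first direct exchange of the two halogens at this place, 4-chlorophenyl to 4-fluorophenyl, gives a 1.2-fold lower number from compound 3 to compound 4 (0.07 log units; within the scatter) in this assay and so leaves the read-out within the scatter. The other two new steps, a 1.2-fold lower number from compound 2 to compound 4 (0.07 log units; within the scatter) and a 1.6-fold higher number from compound 1 to compound 4 (0.20 log units; within the scatter) on exchange of the whole aryl group, also stay within it, so no aryl exchange among these compounds separates from the scatter. No measurement at hand bears on why these numbers stay together.

Going by these compounds, whether an amine or a carboxylic acid in place of the halogen on this ring would move this assay beyond the scatter remains open. Also open, on these data alone, is how much the shared core, rather than the aryl group on the carbonyl, sets the numbers.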